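The compounds below may be only part of what the source reports. "The series", "measured", "known", "first", "only" and "open" are said of these compounds alone.

Two thiosemicarbazones built on one shared core were tested in a functional assay on OVCAR-3 cells (Homo sapiens) for cytotoxicity, read by sulforhodamine B assay; on this read-out lower numbers stand for stronger inhibition of growth and higher numbers for weaker inhibition of growth. Compound 1 `COc1ccc(/C=N\NC(=S)NC(C)(C)CCC[C@](C)(O)[C@@H]2CC=C(C)CC2)cc1` carries a methoxy group on its aromatic ring, and in this assay compound 1 gives 6500 nM. Compound 2 `CC1=CC[C@@H]([C@@](C)(O)CCCC(C)(C)NC(=S)N/N=C\c2ccc(N(C)C)cc2)CC1` carries a dimethylamino group in the same position instead, and in this assay compound 2 gives 3600 nM. The step of a 1.8-fold lower number from compound 1 to compound 2 (0.26 log units; within the scatter) is the only one recorded, and it lies within the scatter, so the two numbers cannot be told apart with confidence.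

Compound 3 `CC1=CC[C@@H]([C@@](C)(O)CCCC(C)(C)NC(=S)N/N=C\c2ccccc2Cl)CC1` has not yet been measured. It differs from compound 2 by 2-chlorophenyl in place of 4-(dimethylamino)phenyl on a carbon with a double bond to nitrogen. For the measured compounds named here, the only measured step that bears on this change, the one from compound 1 to compound 2, also swaps the substituent on this aromatic ring and produced no shift beyond the scatter. On that basis the expected step of a 1.4-fold higher number from compound 2 to compound 3 (0.14 log units; within the scatter) is small, with no clear direction. Compound 3 is therefore estimated to give 5000 nM in this assay, with a plausible range from 1500 nM to 16000 nM.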

Compound 3, concentration for 50% growth inhibition: 42000 nM
Beside the measured number, compound 3's estimate is 8.4-fold (0.92 log units) below it, outside the stated range (above it).
By their numbers in this assay, from the lowest: compounds 2 and 1 (each within the scatter of the next); then compound 3.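

The ring on the carbon with a double bond to nitrogen turns out to matter for growth inhibition in this assay: the earlier swap of methoxy for dimethylamino showed no shift beyond the scatter, but 2-chlorophenyl gives a 12-fold higher number from compound 2 to compound 3 (1.07 log units; beyond the scatter) and likewise a 6.5-fold higher number from compound 1 to compound 3 (0.81 log units; beyond the scatter). So this position does not accept every aromatic group equally, and among these three compounds the 2-chlorophenyl version clearly gives the weakest inhibition of growth, with both of its steps beyond the scatter. Nothing available here explains why this change weakens the effect.

Two things change together in this swap, since 2-chlorophenyl differs from 4-(dimethylamino)phenyl both in the substituent itself and in the number that marks its place on the ring, and these three compounds cannot separate the two. From the compounds shown here alone, it remains open whether the loss follows the chlorine, its place or the absence of the earlier groups, and a plain phenyl ring, or a ring carrying an amine or a carboxylic acid, would show how far this position tolerates other groups.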